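Loss of the Aryl Substituent in an Antiproliferative Series

The compounds below may be only part of what the source reports. "The series", "measured", "known", "first", "only" and "open" are said of these compounds alone.

Compound 1 `O=C1O[C@H]([C@@H](O)Cn2cc(-c3cc(C(F)(F)F)cc(C(F)(F)F)c3)nn2)C(OCc2ccccc2)=C1OCc1ccccc1`: in a functional assay on SW-620 cells (Homo sapiens) for antiproliferative activity, read by MTT assay, with a stated time of 72 h (on this read-out lower numbers stand for stronger inhibition and higher numbers for weaker inhibition), compound 1 gives 49200 nM.
Compound 2 `COc1ccccc1-c1cn(C[C@H](O)[C@H]2OC(=O)C(OCc3ccccc3)=C2OCc2ccccc2)nn1`: in this assay compound 2 gives > 100000 nM, which is a limit of the assay and not a number.

Of the two measured compounds only compound 1 carries a number; compound 2 sits at the limit of > 100000 nM in this assay, at which 1 of the 2 values shown sits, so where it stands relative to compound 1 cannot be told beyond that. Compound 3 `O=C1O[C@H]([C@@H](O)Cn2ccnn2)C(OCc2ccccc2)=C1OCc1ccccc1` differs from compound 2 by hydrogen in place of 2-methoxyphenyl on an aromatic carbon. Within the data shown here, no measured pair differs in only one place, so the size of this step has no precedent among the values shown. With the aryl group gone, the expectation for compound 3 in this assay is a further weakening rather than a gain, and the step is estimated at a step that the limit leaves unreadable from compound 2 to compound 3. Compound 3 is therefore expected to give about 150000 nM, within 40000 nM to 500000 nM, with a fair chance that the assay again reports only a limit.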

Compound 3, half-maximal inhibitory concentration: > 100000 nM
Compound 3: only a limit was reported; the forecaster's own chance of this, stated with the estimate: 65%; the middle value lies beyond the limit too.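

No step from compound 2 to compound 3 can be read, since both compounds give only a limit and not a number: the limit of > 100000 nM in this assay, at which 2 of the 3 values shown sit.

The compounds shown leave open whether hydrogen in place of 2-methoxyphenyl on that aromatic carbon changes activity at all in this assay.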